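The source may report more compounds than this note shows. Statements on the series, on what has been measured and on what is new or still open speak of the compounds shown alone.

Measured so far in a functional assay on JeKo-1 cells (Homo sapiens) for inhibition, read by luminescence and CellTiter-Glo, with a stated time of 72 h; a lower number here means a stronger inhibitor, a higher number a weaker inhibitor:
compound 1, `C/C=C/C(=O)Nc1cccc(Cn2nc(-c3ccc(Oc4ccccc4)cc3)cc2C(=O)O)c1`: > 60000 nM, a limit of this assay rather than a number (the limit of > 60000 nM in this assay, at which 1 of the 3 values shown sits)
compound 2, `CCOC(=O)c1cc(-c2ccc(Oc3ccccc3)cc2)nn1Cc1cccc(NC(=O)CCl)c1`: 400 nM
compound 3, `C/C=C/C(=O)Nc1cccc(Cn2nc(-c3ccc(Oc4ccccc4)cc3)cc2C(=O)OCC)c1`: 16700 nM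

Compound 2 stands lowest among the numbers given; its nearest neighbour is compound 3, reached by a 42-fold higher number from compound 2 to compound 3 (1.62 log units; beyond the scatter). Compound 4, `O=C(CCl)Nc1cccc(Cn2nc(-c3ccc(Oc4ccccc4)cc3)cc2C(=O)O)c1`, has not been measured. It differs from compound 2 by hydrogen in place of ethyl on an oxygen next to a carbonyl group. Among the compounds with values here, the one measured step that bears on this is the reverse change, from compound 1 to compound 3, which gave an at least 3.5-fold lower number from compound 1 to compound 3 (0.55 log units; beyond the scatter). Run the other way, it points to a higher number for compound 4 in this assay, at least modest in size. Compound 4 is therefore expected to give 3000 nM, within 1000 nM to 20000 nM. The expected step is a 7.5-fold higher number from compound 2 to compound 4 (0.88 log units; beyond the scatter).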

Compound 4, half-maximal inhibitory concentration: 6300 nM
The estimate for compound 4 lay 2.1-fold (0.32 log units) below the measured number; measured number inside the range.
By their numbers in this assay, from the lowest: compound 2; then compound 4; then compound 3. At a limit, above all of these: compound 1.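

In this assay, with the chloromethyl amide held fixed, carboxy in place of ethoxycarbonyl now has a measured size, a 16-fold higher number from compound 2 to compound 4 (1.20 log units; beyond the scatter), whereas the earlier step on this change rested on a limit: the same change on two cores in this assay, an at least 3.5-fold lower number (0.55 log units; beyond the scatter) from compound 1 to compound 3 and a 16-fold lower number (1.20 log units; beyond the scatter) from compound 4 to compound 2; the limit leaves it open whether they differ

Chloromethyl in place of prop-1-en-1-yl also lowers the number with the carboxy group present, an at least 9.5-fold lower number from compound 1 to compound 4 (0.97 log units; beyond the scatter), and this step too rests on the limit of compound 1: the same change on two cores in this assay, a 42-fold higher number (1.62 log units; beyond the scatter) from compound 2 to compound 3 and an at least 9.5-fold higher number (0.97 log units; beyond the scatter) from compound 4 to compound 1; the limit leaves it open whether they differ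

The compounds shown leave open how a primary amide or a butyl ester in place of ethoxycarbonyl would read. They also leave open whether a simple methyl in place of chloromethyl would keep any of the number seen for compound 2.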